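Phenyl in place of benzoyl on compound 1

The source may hold more compounds than are shown below. What is called first, only, known or untested is meant among the compounds shown, and "the series" means these compounds.

Within the data shown here, in an ADME assay on microsomes (Rattus norvegicus) for metabolic stability (a higher number here means that the compound lasts longer, a lower number that the compound disappears faster), compound 1 `O=C(c1ccccc1)N1CCC(C(=O)N2N=CCC2c2ccccc2)CC1` gives 0.0833 h and stands as the lower of the two numbers so far. Compound 2 `CC(C)(C)C(=O)N1N=CCC1c1ccccn1` gives 1.32 h and the gap between the two lies beyond the scatter.

The next compound to be read is compound 3 `O=C(C1CCN(c2ccccc2)CC1)N1N=CCC1c1ccccc1`, which keeps the rest of compound 1 and carries phenyl in place of benzoyl on an amine nitrogen in a ring. Among the measured compounds shown here, no measured pair isolates this change, so the data offer no direct precedent for its size. The expectation therefore starts from compound 1 at 0.0833 h and foresees no step beyond the scatter in this assay, with at most a slight lean towards a higher number. The estimated change is a 1.2-fold higher number from compound 1 to compound 3 (0.08 log units; within the scatter) and would leave the half-life short. The expected value for compound 3 is 0.1 h with an estimated range (0.04 h to 0.4 h).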

Compound 3, half-life: 0.25 h
Beside the measured number, compound 3's estimate is 2.5-fold (0.40 log units) below it; low and high end bracket the measured number.
By their numbers in this assay, from the lowest: compound 1; then compound 3; then compound 2.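

In this assay, among these compounds, phenyl in place of benzoyl on an amine nitrogen in a ring gives a 3.0-fold higher number from compound 1 to compound 3 (0.48 log units; beyond the scatter), the first step that reads a change in one place only. It shows that the group on this nitrogen can shift the half-life beyond the scatter while the rest of compound 1 stays the same, although the step is modest and compound 3 still gives only 0.25 h. The six-membered aromatic ring of carbon stays in both compounds and the carbonyl of benzoyl goes, but nothing measured here accounts for the size or direction of the step.

The compounds shown leave open whether the loss of the carbonyl alone accounts for the step, or whether a benzyl, acetyl or sulfonyl group on the same nitrogen would give a similar half-life. They also leave open whether phenyl in place of benzoyl would give a step of similar size with a pyridine ring in place of the phenyl on the other side of the core of compound 1.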